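This account rests on a few compounds, and the source may have more. Where it says the series, first, only, none or still open, it means among the compounds named here.

Three amides have so far been read in a physicochemical assay for solubility, read by nephelometry, measured as kinetic solubility, at pH 2, tested at 10 mg/mL; on this read-out lower numbers stand for lower solubility and higher numbers for higher solubility. In this assay compound 1 `Cc1ccccc1C(=O)Nc1cc(Cl)ccn1` gives 25 ug/mL, compound 2 `Cc1c(F)cccc1C(=O)Nc1cc(Cl)ccn1` gives 12.5 ug/mL and compound 3 `Cc1ccccc1C(=O)Nc1ccc(F)cn1` gives 25 ug/mL. Compound 2 therefore stands within the scatter of both other compounds, and the three numbers do not separate them. Compound 4 `Cc1ccnc(NC(=O)c2cccc(F)c2C)c1` has not yet been measured. It differs from compound 2 by a single change, methyl in place of chloro on an aromatic carbon. Within the data shown here, the only measured step between compounds that differ in one place is a 2.0-fold lower number from compound 1 to compound 2 (0.30 log units; within the scatter), for fluoro in place of hydrogen on an aromatic carbon, and it lies within the scatter. Among the measured compounds shown here, that step involves a different exchange of groups, so it bears on the new change only loosely, and no measured pair exchanges chloro for methyl. With this little evidence, no step beyond the scatter is expected in either direction, and the estimated change is a 2.0-fold higher number from compound 2 to compound 4 (0.30 log units; within the scatter). In this assay the expected value for compound 4 is 25 ug/mL, with an estimated range from 10 ug/mL to 75 ug/mL.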

Compound 4, solubility: > 100 ug/mL
Compound 4: a limit, no number; the forecaster's own chance of this, stated with the estimate: 10%; middle value at least 4.0-fold (0.60 log units) from the limit.
By their numbers in this assay, from the lowest: compounds 2, 1 and 3 (each within the scatter of the next). At a limit, above all of these: compound 4.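

In this assay, methyl in place of chloro, on an aromatic carbon meta to a large group and opposite the ring nitrogen, gives an at least 8.0-fold higher number from compound 2 to compound 4 (0.90 log units; beyond the scatter), and this is the only step shown that lies beyond the scatter. The reading for compound 4 is a limit of the assay and not a number, so the step has a lower bound but no known size: the limit of > 100 ug/mL in this assay, at which 1 of the 4 values shown sits.

Among these compounds, the fluoro exchange, by contrast, gives a 2.0-fold lower number from compound 1 to compound 2 (0.30 log units; within the scatter), so this position on the ring with 1 nitrogen, with this exchange of chloro for methyl, is the first place where a single change clearly separates two compounds.

The compounds shown leave open whether the same exchange of chloro for methyl would give a step of like size on the core of compound 1, which lacks the fluoro, and how far past the limit compound 4 truly lies. They also leave open how a methoxy group, an amine or a longer chain would read at this same position, and so whether methyl is special there or chloro alone holds the number down.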